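The source may report more compounds than this note shows. Statements on the series, on what has been measured and on what is new or still open speak of the compounds shown alone.

Measured compounds:
- compound 1, `CCCCC(O)Cn1cc(CN(C)CC2CCCCC2)nn1`: 47%
- compound 2, `CN(CCCc1ccccc1)Cc1cn(CC(O)COC(=O)NCc2ccccc2)nn1`: 79%
- compound 3, `CN(CCCc1ccccc1)Cc1cn(C2CCCCC2OC(=O)COc2ccccc2)nn1`: 42%

These three compounds were tested in an assay on nucleic acid for inhibition of Nucleic Acid, read by fluorescence, tested at 100 uM; a higher number here means more inhibition at the concentration tested (going by the name of the read-out), a lower number less inhibition. Compound 2 stands highest of the three numbers. The nearest of the others is compound 1, whose result lies well below, beyond the usual scatter of this measurement; compound 3 sits further away still, also beyond the scatter. The inhibition of compound 2 in this assay is therefore the highest among the measured set.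

Compound 4, `CN(CCCc1ccccc1)Cc1cn(CC(O)COC(=O)c2ccccc2)nn1`, has not yet been measured. It differs from compound 2 in one place: phenyl in place of benzylamino on a carbonyl carbon. Among the compounds with values here, no pair of measured compounds shows this particular change, so there is no measured step to lean on; the three measured results share no single-point difference at all.

What can be said rests on compound 2 alone. Its result of 79% in this assay is the starting point, and the change removes the only hydrogen-bond donor counted in the leaving group. The result for compound 4 is expected to come out somewhat lower than that of compound 2, a step of a number 17 percentage points lower from compound 2 to compound 4 (beyond the scatter), of a size that may or may not exceed the scatter.

Compound 4 is estimated at 62%, with a likely range from 40% to 80%.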

Compound 4, a percentage reported as inhibition, at one concentration (the size of the read-out at that concentration, not a potency): 12%
For compound 4 the middle estimate is 50 percentage points above the measured one, and the stated range ends above it.
By their numbers in this assay, from the lowest: compound 4; then compounds 3 and 1 (each within the scatter of the next); then compound 2.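

Within the data shown here, replacing benzylamino with phenyl on a carbonyl carbon in this assay gives a number 67 percentage points lower from compound 2 to compound 4 (beyond the scatter), the first comparison in this set in which only one place differs. It shows that the read-out depends strongly on what sits on this carbonyl carbon, and that keeping an aromatic ring of six carbons there does not preserve the result of compound 2. The change also removes the nitrogen and its hydrogen-bond donor, along with the carbon that links the ring to that nitrogen, and no measurement at hand says which of these differences accounts for the step.

The compounds shown leave open which part of benzylamino matters: anilino on the same carbonyl carbon would keep the nitrogen and lose the linking carbon, while benzyl would keep a linking carbon and lose the nitrogen. They also leave open whether a step of this size would appear on a different core, such as that of compound 3.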